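From diethylamino to (sec-butyl)amino

The source may report more compounds than this note shows. Statements on the series, on what has been measured and on what is new or still open speak of the compounds shown alone.

Among the measured compounds shown here, in an ADME assay on the whole organism for inhibition, with Oryza sativa as the target, with a stated time of 4 days (on this read-out lower numbers stand for stronger inhibition and higher numbers for weaker inhibition), three compounds have numbers so far. Compound 1 `CCCN(CC)c1nc(Cl)nc(N[C@@H](C)c2ccccc2)n1` gives 479 nM as the lowest number. Compound 2 `CCN(CC)c1nc(Cl)nc(N[C@H](C)c2ccccc2)n1` gives 6310 nM and stands second highest of the three, with gaps beyond the scatter on both sides. Compound 3 `CC(C)Nc1nc(Cl)nc(N[C@@H](C)c2ccccc2)n1` gives 23400 nM as the highest number.

Compound 4 `CC[C@@H](C)Nc1nc(Cl)nc(N[C@H](C)c2ccccc2)n1` is an isomer of compound 2, with (sec-butyl)amino in place of diethylamino on an aromatic carbon.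

For the measured compounds named here, one measured step bears on this change. It is a 49-fold higher number from compound 1 to compound 3 (1.69 log units; beyond the scatter) in this assay, a large step beyond the scatter, where isopropylamino replaces ethyl(propyl)amino. There too a group with two chains on the nitrogen gives way to a group with one. That step is not an isomer swap, however. Compound 1 and compound 3 also share one configuration at the other stereocentre, while compound 2 and compound 4 share the opposite one. Going by the values given here, no measured pair separates these factors.

A step in the same direction is therefore expected, but a smaller one. The expected move is a 4.4-fold higher number from compound 2 to compound 4 (0.65 log units; beyond the scatter), towards a higher number and beyond the scatter. For compound 4 the estimate is 28000 nM, within a range of 8000 nM to 90000 nM as expected bounds.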

Compound 4, half-maximal inhibitory concentration: 8320 nM
The estimate for compound 4 lay 3.4-fold (0.53 log units) above the measured number; the range from low to high includes it.
By their numbers in this assay, from the lowest: compound 1; then compounds 2 and 4 (each within the scatter of the next); then compound 3.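

In this assay, replacing diethylamino with (sec-butyl)amino on the aromatic carbon between two ring nitrogen atoms gives a 1.3-fold higher number from compound 2 to compound 4 (0.12 log units; within the scatter), so the read-out does not separate these two groups in this pair. The change adds a hydrogen-bond donor and a defined stereocentre while keeping the heavy-atom count of the group, and in this pair neither addition comes with a step beyond the scatter, which sets it apart from the large step of a 49-fold higher number from compound 1 to compound 3 (1.69 log units; beyond the scatter), where the other stereocentre has the opposite configuration. No measurement here accounts for the contrast between these two steps at the same position.

The compounds shown do not separate the configuration at the other stereocentre from the group on this aromatic carbon, and they do not show how the opposite configuration within (sec-butyl)amino would read. As far as these compounds go, it also remains open whether a longer chain such as dipropylamino, or a cyclic amine such as morpholine, would stay within the scatter of these two groups at this position.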